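Changing one aryl group on compound 3

This account rests on a few compounds, and the source may have more. Where it says the series, first, only, none or still open, it means among the compounds named here.

Going by the values given here, in a functional assay on RT-112 cells (Homo sapiens) for antiproliferative activity, read by MTT assay, with a stated time of 72 h (on this read-out higher numbers stand for weaker inhibition of growth and lower numbers for stronger inhibition of growth), compound 3 (`COc1cc(Nc2ncnc3c(NC(=O)Nc4ccc(F)cc4C(F)(F)F)cccc23)cc(OC)c1`) gives 2970 nM, the highest of the three numbers so far, above compound 1 (`COc1cc(NC(=O)Nc2cccc3c(Nc4cc(OC)cc(OC)c4)ncnc23)cc(OC)c1`) at 366 nM and compound 2 (`COc1cc(Nc2ncnc3c(NC(=O)Nc4cc(Cl)cc(Cl)c4)cccc23)cc(OC)c1`) at 30.2 nM. Compound 4 (`COc1cc(Nc2ncnc3c(NC(=O)Nc4ccc5c(c4)OCCO5)cccc23)cc(OC)c1`) carries 2,3-dihydro-1,4-benzodioxin-6-yl in place of 4-fluoro-2-(trifluoromethyl)phenyl on an amide-type nitrogen. Among the compounds with values here, two measured steps bear on this: an 8.1-fold higher number from compound 1 to compound 3 (0.91 log units; beyond the scatter) and a 98-fold higher number from compound 2 to compound 3 (1.99 log units; beyond the scatter) both rise as that same group enters. Compound 1 is the closest guide, since its 3,5-dimethoxyphenyl group also contains oxygen. From the compounds shown here alone, a drop of similar size to the first step is therefore expected in this assay, though this remains untested. The estimated change is an 8.5-fold lower number from compound 3 to compound 4 (0.93 log units; beyond the scatter) in this read-out. Compound 4 is expected at 350 nM (estimated range 80 nM to 1500 nM).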

Compound 4, concentration for 50% growth inhibition: 2750 nM
Estimate against measurement, compound 4: 7.9-fold (0.90 log units) below; the measured number lies above the stated range.
By their numbers in this assay, from the lowest: compound 2; then compound 1; then compounds 4 and 3 (each within the scatter of the next).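

In this assay, oxygen in the aryl group does not by itself set the number: 2,3-dihydro-1,4-benzodioxin-6-yl gives a 1.1-fold lower number from compound 3 to compound 4 (0.03 log units; within the scatter) and leaves compound 4 level with compound 3, despite its two hydrogen-bond acceptors. The oxygen-bearing groups also differ from each other (a 7.5-fold higher number from compound 1 to compound 4 (0.88 log units; beyond the scatter)), while 3,5-dichlorophenyl remains far ahead at this amide-type nitrogen (a 91-fold higher number from compound 2 to compound 4 (1.96 log units; beyond the scatter)). Nothing available explains these differences.

From the compounds shown here alone, it remains open whether a phenyl ring with a single chlorine would match compound 2, or whether an amine on the ring would change the number.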